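The source may hold more compounds than are shown below. What is called first, only, known or untested is meant among the compounds shown, and "the series" means these compounds.

Measured so far in a functional assay on B16-F10 cells (Mus musculus) for inhibition, read by MTT assay, with a stated time of 72 h; on this read-out higher numbers stand for weaker inhibition and lower numbers for stronger inhibition:
compound 1, `C#CCSc1nc(Nc2ccc(OC)cc2)c(C#N)c(-c2ccccc2)n1`: 9710 nM
compound 2, `C#CCSc1nc(Nc2cccc(Cl)c2)c(C#N)c(-c2ccccc2)n1`: 10500 nM
compound 3, `N#Cc1c(Nc2cccc(C(F)(F)F)c2)nc(SCc2cn(Cc3ccccc3Cl)nn2)nc1-c1ccccc1`: 3710 nM

Compound 3 stands lowest of the three numbers; compound 1 and compound 2 both sit higher, and both gaps lie beyond the usual scatter. Compound 1 and compound 2 differ only in the aryl group on the nitrogen on the aromatic ring, and the step of a 1.1-fold higher number from compound 1 to compound 2 (0.03 log units; within the scatter) lies within the scatter.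

Compound 4, `COc1ccccc1Nc1nc(SCc2cn(Cc3ccccc3Cl)nn2)nc(-c2ccccc2)c1C#N`, is not yet measured. It differs from compound 3 by 2-methoxyphenyl in place of 3-(trifluoromethyl)phenyl on a nitrogen on an aromatic ring. Among the measured compounds shown here, the only measured step that touches the same place is a 1.1-fold higher number from compound 1 to compound 2 (0.03 log units; within the scatter), an exchange of one aryl group for another on the same nitrogen that left the number unchanged within the scatter. That is thin ground: the substituents involved are different, and the rest of compound 1 and compound 2 differs from that of compound 3 and compound 4. For the measured compounds named here, still, on the single comparison available, no step beyond the scatter is expected in this assay from compound 3 to compound 4, in either direction. Compound 4 is therefore expected to give about 4500 nM, within a range from 2000 nM to 10000 nM. The step this estimate implies is expected to be a 1.2-fold higher number from compound 3 to compound 4 (0.08 log units; within the scatter).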

Compound 4, half-maximal inhibitory concentration: 7860 nM
For compound 4 the middle estimate is 1.7-fold (0.24 log units) below the measured one; low and high end bracket the measured number.
By their numbers in this assay, from the lowest: compound 3; then compounds 4, 1 and 2 (each within the scatter of the next).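

In this assay the exchange of 3-(trifluoromethyl)phenyl for 2-methoxyphenyl on this nitrogen gives a 2.1-fold higher number from compound 3 to compound 4 (0.33 log units; beyond the scatter), so the aryl group at this place can move the number beyond the scatter, a modest step but one that a 1.1-fold higher number from compound 1 to compound 2 (0.03 log units; within the scatter) did not show. The two exchanges involve different aryl groups on different remainders of the molecule, so the data cannot tell whether the aryl groups themselves or the rest of the structure sets the size of each step. No measurement shown here bears on the origin of this step.

From the compounds shown here alone, the step from compound 3 to compound 4 changes both the substituent and its place on the phenyl ring, so it remains open which of the two matters; 3-methoxyphenyl and 2-(trifluoromethyl)phenyl on the same remainder would separate them. Going by these compounds, it also remains open how an unsubstituted phenyl, or an aryl group carrying an amine or a carboxylic acid, would read on this nitrogen.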